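The source may report more compounds than this note shows. Statements on the series, on what has been measured and on what is new or still open speak of the compounds shown alone.

Working notes on the series. The shared core is that of compound 1 `CC(C)(C)N(NC(=O)c1ccccc1)C(=O)c1ccccc1F`, which in an assay on cells for agonist activity at ecdysone receptor (Bombyx mori), read by a luciferase reporter, with a stated time of 24 h (a higher number here means that more compound is needed for the effect, a lower number that less compound is needed), gives 309 nM. Compound 2 `CC(C)(C)N(NC(=O)c1ccccc1)C(=O)c1ccccc1C(F)(F)F` gives 631 nM in this assay, and compound 3 `CC(C)(C)N(NC(=O)c1ccccc1I)C(=O)c1ccccc1Cl` gives 1290 nM. Compound 3 therefore stands at the highest of the three numbers, with compound 2 nearest and compound 1 furthest. Within the data shown here, the only single-place step measured, a 2.0-fold higher number from compound 1 to compound 2 (0.31 log units; beyond the scatter), lies on the carbonyl carbon bonded to the tert-butyl-bearing nitrogen and is modest.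

Compound 4 `CC(C)(C)N(NC(=O)c1cccc(C#N)c1)C(=O)c1ccccc1Cl` differs from compound 3 by 3-cyanophenyl in place of 2-iodophenyl on a carbonyl carbon. Among the measured compounds shown here, no measured step touches this carbonyl, so nothing in the data directly sizes the change. What can be said is that compound 1, with an unsubstituted phenyl on the carbonyl carbon whose other neighbour is the amide-type nitrogen, gives 309 nM, and compound 2 with the same phenyl gives 631 nM, both lower than compound 3, though each also differs from compound 3 on the other carbonyl. On that basis a step of a 1.8-fold lower number from compound 3 to compound 4 (0.27 log units; within the scatter) is expected for compound 4, held loosely. Compound 4 is estimated at 700 nM in this assay, with a range from 250 nM to 2000 nM.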

Compound 4, half-maximal effective concentration: 955 nM
Beside the measured number, compound 4's estimate is 1.4-fold (0.13 log units) below it; measured number inside the range.
By their numbers in this assay, from the lowest: compound 1; then compounds 2, 4 and 3 (each within the scatter of the next, the first and the last beyond it).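

Among these compounds, this is the first measured step on the carbonyl carbon whose other neighbour is the amide-type nitrogen: in this assay, 3-cyanophenyl in place of 2-iodophenyl gives a 1.4-fold lower number from compound 3 to compound 4 (0.13 log units; within the scatter). The exchange replaces the iodine with a nitrile and adds a hydrogen-bond acceptor to the group at this place, yet the two numbers cannot be told apart, so in this pair the assay shows no effect of the change, unlike the step on the other carbonyl, which lies beyond the scatter. Among the compounds shown here, nothing at hand gives a reason for this result, and the single step cannot show how the loss of the iodine and the arrival of the nitrile each contribute.

The compounds shown leave open whether a plain phenyl at this place, with the 2-chlorophenyl group of compound 3 kept on the other carbonyl, would give a similar number, since compounds 1 and 2 differ from compound 3 in more than one place. Also open, on these data alone, is whether a phenyl carrying an amine or a carboxylic acid would remain within the scatter of compound 3 and compound 4.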